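Chain extension from compound 3 to compound 4

The compounds below may be only part of what the source reports. "The series", "measured", "known", "first", "only" and "open" are said of these compounds alone.

Measured in a functional assay on NCI-H630 cells (Homo sapiens) for cytotoxicity, read by sulforhodamine B assay, with a stated time of 5 days (a higher number here means a weaker inhibitor, a lower number a stronger inhibitor), as follows
compound 1 `O=C(CCCCCc1ccccc1)N[C@H]1CCOC1=O` gives > 100000 nM as a limit of the assay
compound 2 `O=C(CCCCc1ccccc1)CC(=O)N[C@H]1CCOC1=O` gives 80000 nM as a number
compound 3 `O=C(CCCCCc1ccccc1)CC(=O)N[C@H]1CCOC1=O` gives 24000 nM as a number

Compound 3 stands lowest of the two true numbers in this assay and is the starting point here. Compound 1 stands at the limit of > 100000 nM in this assay, at which 1 of the 3 values shown sits, and no step size can be read from it.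

The next structure is compound 4 `O=C(CCCCCCCc1ccccc1)CC(=O)N[C@H]1CCOC1=O` and the change is phenethyl in place of phenyl on a saturated chain carbon, five bonds along the chain from a carbonyl carbon on the same chain. Going by the values given here, one measured step bears on this, namely a 3.3-fold lower number from compound 2 to compound 3 (0.52 log units; beyond the scatter) which was modest and also extended that chain. A further fall in the same direction is expected, of similar or somewhat larger size, although a single step does not establish a trend. The expected step is a 2.7-fold lower number from compound 3 to compound 4 (0.43 log units; beyond the scatter) with a wide margin on either side. For compound 4 the estimated value is 9000 nM with an expected range from 3000 nM to 30000 nM in this assay at this stage.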

Compound 4, half-maximal inhibitory concentration: 10000 nM
Estimate against measurement, compound 4: 1.1-fold (0.05 log units) below, and the stated range covers the measured number.
By their numbers in this assay, from the lowest: compound 4; then compound 3; then compound 2. At a limit, above all of these: compound 1.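

In this assay, the longer chain again gives a lower number: a 2.4-fold lower number from compound 3 to compound 4 (0.38 log units; beyond the scatter). This follows a 3.3-fold lower number from compound 2 to compound 3 (0.52 log units; beyond the scatter), so a second extension at this position moves the same way, and across compounds 2, 3 and 4 the number falls with each extension, with neither step within the scatter. Compound 1 stands at a limit of the assay, and steps to it cannot be read because its value is not a number: the limit of > 100000 nM in this assay, at which 1 of the 4 values shown sits.

The series leaves open whether a still longer chain would lower the number further or reverse the fall. It also leaves open how a chain ending in an amine or a carboxylic acid in place of the phenyl would read in this assay.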